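Cytotoxicity of a bicyclic thymidine sulfonate series in HEL cells

A few compounds are considered here, and "the series" means these few. Any claim that something is new, unique, unknown or untested is made for them only; others in the source may bear on it.

Compound 1 `CC(=O)NC1=CS(=O)(=O)O[C@@]12[C@@H](CO[Si](C)(C)C(C)(C)C)O[C@@H](n1cc(C)c(=O)n(C)c1=O)[C@@H]2O[Si](C)(C)C(C)(C)C`: in a functional assay on HEL cells (Homo sapiens) for cytotoxicity, read by microscopy (on this read-out higher numbers stand for lower toxicity in this test and lower numbers for higher toxicity in this test), compound 1 gives only a limit, >= 80000 nM.
Compound 2 `COC(=O)CNC1=CS(=O)(=O)O[C@@]12[C@@H](CO[Si](C)(C)C(C)(C)C)O[C@@H](n1cc(C)c(=O)n(C)c1=O)[C@@H]2O[Si](C)(C)C(C)(C)C`: in this assay compound 2 gives only a limit, >= 400000 nM.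
Compound 3 `Cc1cn([C@@H]2O[C@H](CO[Si](C)(C)C(C)(C)C)[C@@]3(OS(=O)(=O)C=C3NCC(=O)OCc3ccccc3)[C@H]2O[Si](C)(C)C(C)(C)C)c(=O)n(C)c1=O`: in this assay compound 3 gives only a limit, >= 400000 nM.

Compound 1 stands at a limit, as do the two other measured compounds; none returned a number. Compound 4 `Cc1cn([C@@H]2O[C@H](CO[Si](C)(C)C(C)(C)C)[C@@]3(OS(=O)(=O)C=C3NCCC(N)=O)[C@H]2O[Si](C)(C)C(C)(C)C)c(=O)n(C)c1=O` differs from compound 1 by 2-carbamoylethyl in place of acetyl on an amine nitrogen. The steps on the same amine nitrogen, a step that the two limits leave unreadable from compound 1 to compound 2 and a step that the two limits leave unreadable from compound 1 to compound 3, are both unreadable because the limit of >= 400000 nM in this assay, at which 2 of the 3 values shown sit, and the limit of >= 80000 nM in this assay, at which 1 of the 3 values shown sits, are limits only. The step from compound 2 to compound 3, a step that the two limits leave unreadable from compound 2 to compound 3, is likewise unreadable. For compound 4 a limit is again expected, with the step that the limit leaves unreadable from compound 1 to compound 4 carrying no readable direction. The estimate for compound 4 is 200000 nM, between 80000 nM and 400000 nM.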

Compound 4, minimum cytotoxic concentration: >= 80000 nM
Compound 4 gave a limit, no number; the forecaster's own chance of this, stated with the estimate: 85%; the middle value is on the limit's open side.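

Compound 4 gave only a limit, as did compound 1, compound 2 and compound 3, so none of its steps to them can be read. The compounds shown leave open whether any group on the amine nitrogen changes the result in this assay.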